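Amide substituent variation: notes toward compound 4

The compounds below may be only part of what the source reports. "The series", "measured", "known", "first", "only" and "open" are said of these compounds alone.

Three compounds share one core: compound 1 `CC(C)(C)OC[C@@H](N)C(=O)N1CCN(CCCOc2ccc(C(=O)C3CC3)cc2)CC1`, compound 2 `CC(C)(C)[C@@H](N)C(=O)N1CCN(CCCOc2ccc(C(=O)C3CC3)cc2)CC1` and compound 3 `CCCCCC(=O)c1ccc(OCCCN2CCN(C(=O)[C@H](CC(C)C)NC(=O)OC(C)(C)C)CC2)cc1`. In an assay for binding affinity to histamine H2 receptor (Homo sapiens) (a lower number here means a stronger inhibitor, a higher number a weaker inhibitor), compound 1 gives 45700 nM, compound 2 gives 19100 nM and compound 3 gives 3470 nM. Compound 2 stands second highest of the three numbers, nearest to compound 1 and furthest from compound 3. The only measured step among these, a 2.4-fold lower number from compound 1 to compound 2 (0.38 log units; beyond the scatter), is modest. Compound 4 `CN[C@@H](C(=O)N1CCN(CCCOc2ccc(C(=O)C3CC3)cc2)CC1)C(C)C` rearranges the same atoms: 2-methyl-1-(methylamino)propyl in place of 1-amino-2,2-dimethylpropyl on a carbonyl carbon. For the measured compounds named here, no measured step covers this rearrangement; the step from compound 1 to compound 2 shows only that changing the group on a carbonyl carbon moves the number modestly. The expected step is therefore a 1.3-fold lower number from compound 2 to compound 4 (0.10 log units; within the scatter), with no firm direction. Compound 4 is estimated at 15000 nM, range 5000 nM to 45000 nM.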

Compound 4, inhibition constant: 49000 nM
Compound 4: middle estimate off by 3.3-fold (0.51 log units), on the low side, outside the stated range (above it).
By their numbers in this assay, from the lowest: compound 3; then compound 2; then compounds 1 and 4 (each within the scatter of the next).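

On a carbonyl carbon whose other neighbours are amide-type nitrogen in a ring, the same atoms joined differently read differently: in this assay 2-methyl-1-(methylamino)propyl in place of 1-amino-2,2-dimethylpropyl gives a 2.6-fold higher number from compound 2 to compound 4 (0.41 log units; beyond the scatter) at this position. In place of 1-amino-2-(tert-butoxy)ethyl, the same group gives a 1.1-fold higher number from compound 1 to compound 4 (0.03 log units; within the scatter) and so is not distinguished from it here. No available evidence accounts for the step from compound 2 to compound 4.

Still open, as far as these compounds go, is whether the methyl on the amine nitrogen or the rearranged carbon chain carries that step, and how a dimethylamino group or a hydroxyl group would read on this carbon.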